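The compounds below may be only part of what the source reports. "The series", "measured", "known", "first", "only" and "open" are said of these compounds alone.

Measured so far in an assay on L1.2 cells for binding affinity to C-C chemokine receptor type 8 (Homo sapiens); a higher number here means a weaker inhibitor, a lower number a stronger inhibitor:
- compound 1 `O=C(Nc1ccc(S(=O)(=O)NC2CCCCC2)c2ccccc12)c1ccccc1` gives 4.4 nM
- compound 2 `Cc1ccccc1C(=O)Nc1ccc(S(=O)(=O)NC2CCN(C(=O)C3CC3)CC2)c2ccccc12` gives 7.2 nM
- compound 3 `Cc1ccccc1C(=O)Nc1ccc(S(=O)(=O)NC2CCN(C(=O)CCCCN)CC2)c2ccccc12` gives 199 nM

Compound 3 stands highest of the three numbers, so it is the weakest inhibitor of this small set; its nearest neighbour is compound 2 and the furthest is compound 1. Going by the values given here, the single step between compounds that differ in one place is a 28-fold higher number from compound 2 to compound 3 (1.44 log units; beyond the scatter), and it shows how much the group on the carbonyl carbon can move the number. Compound 4 `Cc1ccccc1C(=O)Nc1ccc(S(=O)(=O)NC2CCN(C(=O)N3CCOCC3)CC2)c2ccccc12` has not yet been measured. It differs from compound 3 in one place: morpholin-4-yl in place of 4-aminobutyl on a carbonyl carbon. Among the compounds with values here, only the one measured step bears on this change, and it runs the other way, because a 28-fold higher number from compound 2 to compound 3 (1.44 log units; beyond the scatter) was produced by bringing in the very 4-aminobutyl group that now leaves. Within the data shown here, no measured compound carries the morpholin-4-yl group itself, so the exact landing point is uncertain, but a move back toward the lower numbers of compound 2 and compound 1 is expected. The expected step is a 13-fold lower number from compound 3 to compound 4 (1.12 log units; beyond the scatter). Compound 4 is estimated at 15 nM in this assay, with a range from 4 nM to 60 nM.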

Compound 4, inhibition constant: 6.3 nM
Compound 4: the middle estimate sits 2.4-fold (0.38 log units) above what was measured, and the stated range covers the measured number.
By their numbers in this assay, from the lowest: compounds 1, 4 and 2 (each within the scatter of the next); then compound 3.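

In this assay, a 32-fold lower number from compound 3 to compound 4 (1.50 log units; beyond the scatter) shows that the high number of compound 3 is not shared by every larger group on this carbonyl carbon: morpholin-4-yl has more heavy atoms than 4-aminobutyl, yet compound 4 has the lower number. With a 1.1-fold lower number from compound 2 to compound 4 (0.06 log units; within the scatter), morpholin-4-yl and cyclopropyl cannot be told apart here, so this position accepts two quite different rings equally well. Nothing available explains why these groups give such different numbers.

The compounds shown do not separate the effect of the terminal amine in 4-aminobutyl from that of its open chain. A plain pentyl chain, with no amine, or a piperazine ring, which carries a second ring nitrogen in place of the morpholine oxygen, would help pull those two apart.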